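Oxazole substituent series: bromo in place of isopropyl

The source may hold more compounds than are shown below. What is called first, only, known or untested is meant among the compounds shown, and "the series" means these compounds.

Measured so far:
compound 1 `CC(C)(C)c1ccc(-c2cnc(Nc3cccc4c3CC(O)CC4)o2)cc1`, 26 nM
compound 2 `CCc1nc(Nc2cccc3c2CC(O)CC3)oc1-c1ccc(C(F)(F)F)cc1`, 2.1 nM
compound 3 `CC(C)c1nc(Nc2cccc3c2CC(O)CC3)oc1-c1ccc(C(F)(F)F)cc1`, 114 nM

In an in vitro functional assay on cells for antagonist activity at transient receptor potential cation channel subfamily V member 1 (Homo sapiens), read by FLIPR and calcium flux (on this read-out lower numbers stand for stronger inhibition and higher numbers for weaker inhibition), compound 3 gives the highest number of the three, with compound 1 nearest and compound 2 furthest. For the measured compounds named here, the single directly comparable step is a 54-fold higher number from compound 2 to compound 3 (1.73 log units; beyond the scatter), showing that the group on this oxazole carbon moves the read-out strongly. Compound 4 `OC1CCc2cccc(Nc3nc(Br)c(-c4ccc(C(F)(F)F)cc4)o3)c2C1` differs from compound 3 by bromo in place of isopropyl on an aromatic carbon. Going by the values given here, with only one step at this position, the direction of going from isopropyl to bromo is not fixed by the data, but the large swing from compound 2 to compound 3 makes a substantial move likely; a lower number than compound 3 is expected. Compound 4 is estimated at 10 nM, range 2 nM to 50 nM, which means an 11-fold lower number from compound 3 to compound 4 (1.06 log units; beyond the scatter).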

Compound 4, half-maximal inhibitory concentration: 9 nM
Compound 4: middle estimate off by 1.1-fold (0.05 log units), on the high side; low and high end bracket the measured number.
By their numbers in this assay, from the lowest: compound 2; then compound 4; then compound 1; then compound 3.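

In this assay, the high number seen with isopropyl does not extend to every group on this aromatic carbon, as bromo gives a 13-fold lower number from compound 3 to compound 4 (1.10 log units; beyond the scatter) for this change. Bromo does not fully match ethyl, leaving a 4.3-fold higher number from compound 2 to compound 4 (0.63 log units; beyond the scatter) as the remaining gap. On this carbon, ethyl, bromo and isopropyl now rank from lowest number to highest, with each step beyond the scatter.

Going by these compounds, whether a methyl, a chloro or a nitrile here would fall nearer ethyl or bromo remains open. Nothing available bears on why the three groups fall in this order.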